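Azido for Iodo Across Two Cores: Expected Step

The compounds below may be only part of what the source reports. "The series", "measured", "known", "first", "only" and "open" are said of these compounds alone.

In a functional assay on HFF cells (Homo sapiens) for cytotoxicity (on this read-out higher numbers stand for weaker inhibition and lower numbers for stronger inhibition), compound 1 `CC(=O)OC1C(CI)OC(n2c(Cl)nc3cc(Cl)c(Cl)cc32)C1OC(C)=O` gives 32000 nM. Compound 2 `CC(=O)OC1C(CN=[N+]=[N-])OC(n2c(Cl)nc3cc(Cl)c(Cl)cc32)C1OC(C)=O`, which carries azido in place of iodo on a saturated chain carbon bound to a saturated ring carbon, gives 32000 nM in this assay, and the step of no change at the digits printed from compound 1 to compound 2 (within the scatter) lies within the scatter. Compound 3 `O[C@@H]1[C@@H](CI)OC(n2c(Cl)nc3cc(Cl)c(Cl)cc32)[C@@H]1O` gives 32000 nM in this assay, level with compounds 1 and 2; the difference between the core of compound 1 and the core of compound 3 is not broken down here. Compound 4 `[N-]=[N+]=NC[C@H]1OC(n2c(Cl)nc3cc(Cl)c(Cl)cc32)[C@H](O)[C@@H]1O` is not yet measured. It carries azido in place of iodo on a saturated chain carbon bound to a saturated ring carbon, the same change as that between compound 1 and compound 2, at the same place. Because the earlier step was no change at the digits printed from compound 1 to compound 2 (within the scatter), a flat step is expected here as well, no change at the digits printed from compound 3 to compound 4 (within the scatter). Compound 4 is therefore estimated at 32000 nM in this assay, with a range from 16000 nM to 64000 nM.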

Compound 4, half-maximal inhibitory concentration: 32000 nM
For compound 4 middle estimate and measured number coincide at the digits printed; measured number inside the range.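

In this assay, azido in place of iodo on a saturated chain carbon bound to a saturated ring carbon gives no change at the digits printed from compound 3 to compound 4 (within the scatter). Set beside the same change on the core of compound 1, the step carries over unchanged: the same change on two cores in this assay, no change at the digits printed (within the scatter) from compound 1 to compound 2 and no change at the digits printed (within the scatter) from compound 3 to compound 4, 1.0-fold (0.00 log units) apart, within the scatter of two such steps

This transfer is shown for these two cores only, with all four compounds level, so it does not show that the change would stay flat on a core where the iodomethyl compound reads differently, or in any read-out other than this assay.

Open, on these data alone, is whether another group at this place, such as an amine, a carboxylic acid or a longer chain, would shift the number in this assay. As far as these compounds go, whether the flat step holds on a third core also remains open.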